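Fluoro for Methyl on the Anilino Ring of Compound 3

This account rests on a few compounds, and the source may have more. Where it says the series, first, only, none or still open, it means among the compounds named here.

This account follows a small series of thiophene-based compounds sharing one core and differing at the ring attached through the amino group. Compound 1 `COC(=O)c1c(Nc2ccc(F)cc2)sc(C(=O)c2ccc(OC)cc2)c1C` carries a methyl ester on the core and gives 25.6% in a functional assay, with a stated time of 150 min, tested at 35 ug/mL; on this read-out higher numbers stand for a stronger effect at the one concentration tested and lower numbers for a weaker effect. Compound 2 `COc1ccc(C(=O)c2sc(Nc3ccccc3)c(C(=O)O)c2C)cc1`, which carries the free acid and an unsubstituted phenyl ring, gives 61.2%. Compound 3 `COc1ccc(C(=O)c2sc(Nc3ccc(C)cc3)c(C(=O)O)c2C)cc1`, the free acid with a 4-methylphenyl ring, is reported only as "not active" (no number reported), so no single number places it on the scale; it stands below the two numbered results in the sense that no activity was recorded for it.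

The step of interest leads from compound 3 to compound 4 `COc1ccc(C(=O)c2sc(Nc3ccc(F)cc3)c(C(=O)O)c2C)cc1`, the free acid bearing the (4-fluorophenyl)amino group. The change is fluoro in place of methyl on an aromatic carbon. For the measured compounds named here, no measured pair in this set isolates that single change, so the size of its effect is not known from the data. Compound 4 is expected to show some activity, because the closely related compound 2 gives 61.2% and compound 1 gives 25.6%, with the outcome for compound 4 estimated at 35% within a range of 5% to 65%.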

Compound 4, a percentage reported as activity, at one concentration (the size of the read-out at that concentration, not a potency): 12.8%
Estimate against measurement, compound 4: 22.2 percentage points above, and the stated range covers the measured number.
By their numbers in this assay, from the lowest: compound 4; then compound 1; then compound 2.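

In this assay, the free acid with the 4-fluorophenyl group has a measured number, whereas compound 3, with the 4-methylphenyl group, has none, so the fluoro-for-methyl step and any other step from compound 3 cannot be read. Fluoro in place of hydrogen on this aromatic carbon gives the first sized result for this position in the free-acid compounds (a number 48.4 percentage points lower from compound 2 to compound 4 (beyond the scatter)), showing that the position is not indifferent to substitution in this pair. With the 4-fluorophenyl group held fixed, hydrogen in place of methyl on an oxygen next to a carbonyl group also separates two compounds by a single change (a number 12.8 percentage points lower from compound 1 to compound 4 (beyond the scatter)), and that step runs towards the lower number, which compounds 1 and 2, differing in two places, could not show.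

The compounds shown leave open how chloro, methoxy or an amine on this same aromatic carbon would read out, and whether the methyl ester of compound 2 or compound 3 would follow the same direction. Nothing among the data shown gives a reason for these steps.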